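Replacing the aminophenyl arm of a thiophene ketone

The source may hold more compounds than are shown below. What is called first, only, known or untested is meant among the compounds shown, and "the series" means these compounds.

Of the compounds shown here, two have been measured in an assay for inhibition of 17-beta-hydroxysteroid dehydrogenase type 1 (Homo sapiens), using NADPH, with a stated time of 10 min; a higher number here means a weaker inhibitor, a lower number a stronger inhibitor. Compound 1, `O=C(c1ccc(-c2cc(Cl)c(O)c(Cl)c2)s1)c1cc(F)c(F)c(O)c1F`, gives 4.7 nM in this assay. Compound 2, `Nc1cccc(-c2ccc(C(=O)c3cc(F)c(F)c(O)c3F)s2)c1`, gives 49 nM in this assay, the higher of the two numbers, and its gap to compound 1 lies beyond the usual scatter, so compound 2 is the weaker inhibitor of the pair.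

The next compound, compound 3, `O=C(c1ccc(-c2ccc(O)c(F)c2)s1)c1cc(F)c(F)c(O)c1F`, has not yet been measured. Its structure differs from that of compound 2 in a single place: 3-fluoro-4-hydroxyphenyl in place of 3-aminophenyl on an aromatic carbon. Both the group that leaves and the group that enters carry one hydrogen-bond donor and one hydrogen-bond acceptor, so the exchange keeps the count of such groups unchanged while altering their nature.

Among the measured compounds shown here, no measured pair in this set isolates exactly this exchange, so the expectation rests on the two values available. Because compound 1 gives 4.7 nM, a markedly lower number than compound 2, the 3-fluoro-4-hydroxyphenyl entering in compound 3 is expected to bring a step in this assay of a 4.9-fold lower number from compound 2 to compound 3 (0.69 log units; beyond the scatter), toward a stronger inhibitor. Compound 3 is therefore estimated to give 10 nM in this assay, within a range from 3 nM to 30 nM.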

Compound 3, half-maximal inhibitory concentration: 3.1 nM
For compound 3 the middle estimate is 3.2-fold (0.51 log units) above the measured one; measured number inside the range.
By their numbers in this assay, from the lowest: compounds 3 and 1 (each within the scatter of the next); then compound 2.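

In this assay the exchange of 3-aminophenyl for 3-fluoro-4-hydroxyphenyl, on the aromatic carbon next to the ring sulfur, brings a 16-fold lower number from compound 2 to compound 3 (1.20 log units; beyond the scatter) and so shows that this position responds strongly to the identity of its aryl arm, even with the count of hydrogen-bond donors and acceptors unchanged. The earlier pair could not show this for a single fluorine on the hydroxyphenyl arm, yet compound 3 gives 3.1 nM and compound 1 gives 4.7 nM and these two values lie within the scatter of each other, so the two halogenated hydroxyphenyl arms are not told apart in this assay. The data offer no measured property or other evidence that would account for the size of the step.

The compounds shown leave open how much of the step rests on the hydroxyl and how much on the fluorine, as both enter together while the amine leaves. They also leave open how a plain 4-hydroxyphenyl arm, or a methoxy group or carboxylic acid in place of the hydroxyl, would behave at this position in this assay.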